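Notes on the nitrogen substituent in a sulfamate series

The compounds below may be only part of what the source reports. "The series", "measured", "known", "first", "only" and "open" are said of these compounds alone.

Measured compounds:
compound 1 `NS(=O)(=O)OC[C@@H]1C[C@@H](n2nnc3c(NCCCc4ccccc4)ncnc32)C[C@@H]1O`: 149 nM
compound 2 `CCCCCCNc1ncnc2c1nnn2[C@@H]1C[C@@H](COS(N)(=O)=O)[C@@H](O)C1`: 21.1 nM

In an assay on a protein complex for inhibition of NEDD8 activating enzyme (Homo sapiens), read by HTRF, with a stated time of 2 h, in the presence of a further agent that is not named here (on this read-out higher numbers stand for weaker inhibition and lower numbers for stronger inhibition), compound 2 holds the lowest of the two numbers, set apart by the step of a 7.1-fold lower number from compound 1 to compound 2 (0.85 log units; beyond the scatter). Compound 3 `NS(=O)(=O)OC[C@@H]1C[C@@H](n2nnc3c(Nc4n[nH]c5ccccc45)ncnc32)C[C@@H]1O` differs from compound 2 by 1H-indazol-3-yl in place of hexyl on a nitrogen on an aromatic ring. Within the data shown here, the single measured step swaps phenyl for propyl further out on the chain and bears on this change only loosely; no measured compound carries an aromatic group on the nitrogen on the aromatic ring. The change is therefore expected to move the number upward by a 7.1-fold higher number from compound 2 to compound 3 (0.85 log units; beyond the scatter), with wide uncertainty. For compound 3 the estimate in this assay is 150 nM, expected to fall between 30 nM and 800 nM.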

Compound 3, half-maximal inhibitory concentration: > 10000 nM
Compound 3: only a limit was reported; the forecaster's own chance of this, stated with the estimate: 10%; middle value at least 66-fold (1.82 log units) from the limit.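

Compound 3 gives only a limit in this assay: the limit of > 10000 nM in this assay, at which 1 of the 3 values shown sits. At the nitrogen on an aromatic ring, 1H-indazol-3-yl in place of hexyl gives an at least 470-fold higher number from compound 2 to compound 3 (2.67 log units; beyond the scatter), and in place of 3-phenylpropyl it gives an at least 67-fold higher number from compound 1 to compound 3 (1.82 log units; beyond the scatter). Both steps exceed the one between the two chains, a 7.1-fold lower number from compound 1 to compound 2 (0.85 log units; beyond the scatter), so this change to an aromatic group on the nitrogen weighs far more here than the chain change did.

Going by these compounds, it remains open whether the loss belongs to 1H-indazol-3-yl alone or extends to other aromatic groups on this nitrogen. A phenyl or a cyclohexyl at the same place would separate these readings.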